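Aryl variation and antiproliferative activity: compound 3 to compound 4

The source may hold more compounds than are shown below. What is called first, only, known or untested is meant among the compounds shown, and "the series" means these compounds.

Measured so far:
- compound 1 `CCC1=C(O)c2c(oc(-c3ccc(O)cc3)cc2=O)C(CC)(CC)C1=O`: 20.6 uM
- compound 2 `CCC1=C(O)c2c(oc(-c3ccc(F)cc3)cc2=O)C(CC)(CC)C1=O`: 1.85 uM
- compound 3 `CCC1=C(O)c2c(oc(-c3ccccc3F)cc2=O)C(CC)(CC)C1=O`: 3.93 uM

All three values come from a functional assay on KBVIN cells (Homo sapiens) for antiproliferative activity, read by sulforhodamine B assay, with a stated time of 3 days; on this read-out higher numbers stand for an effect only at larger amounts of compound and lower numbers for an effect already at smaller amounts. Compound 3 holds the second highest of the three numbers, with a 2.1-fold higher number from compound 2 to compound 3 (0.33 log units; beyond the scatter) and a 5.2-fold lower number from compound 1 to compound 3 (0.72 log units; beyond the scatter) setting it apart from its two neighbours.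

The next compound is compound 4 `CCC1=C(O)c2c(oc(-c3ccc(OC)c(C)c3)cc2=O)C(CC)(CC)C1=O`, which carries 4-methoxy-3-methylphenyl in place of 2-fluorophenyl on an aromatic carbon next to the ring oxygen: 4-methoxy-3-methylphenyl in place of 2-fluorophenyl on an aromatic carbon.

Going by the values given here, no measured compound carries methoxy or methyl on this aryl ring, so direct evidence is lacking. The largest measured change is an 11-fold lower number from compound 1 to compound 2 (1.05 log units; beyond the scatter), and it removes the hydroxy group that compound 4 also lacks. The change between the two fluorinated aryl groups, a 2.1-fold higher number from compound 2 to compound 3 (0.33 log units; beyond the scatter), is modest and gives the better guide to variation among aryl groups without hydroxy. Compound 4 is therefore expected to stay near compound 3, with no step beyond the scatter in this assay. The estimated step is a 1.3-fold lower number from compound 3 to compound 4 (0.12 log units; within the scatter). The expected value for compound 4 is 3 uM, with an estimated range from 1 uM to 9 uM.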

Compound 4, concentration for half-maximal effect: 0.1 uM
Estimate against measurement, compound 4: 30-fold (1.48 log units) above, and the stated range ends above it.
By their numbers in this assay, from the lowest: compound 4; then compound 2; then compound 3; then compound 1.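

In this assay, the aryl group on this aromatic carbon next to the ring oxygen has far more influence than the two fluorinated compounds suggested: their difference was only a 2.1-fold higher number from compound 2 to compound 3 (0.33 log units; beyond the scatter), whereas 4-methoxy-3-methylphenyl gives a 39-fold lower number from compound 3 to compound 4 (1.59 log units; beyond the scatter) and a 19-fold lower number from compound 2 to compound 4 (1.27 log units; beyond the scatter). Going by these compounds alone, removing the hydroxy group is therefore not the only large change available here, since the aryl groups without hydroxy also differ widely, and the full span across the series reaches a 210-fold lower number from compound 1 to compound 4 (2.31 log units; beyond the scatter), with compound 4 now holding the lowest number by steps beyond the scatter to all three others. Nothing in the data explains why this aryl group stands so far from the others.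

Compound 4 carries methoxy and methyl together, so the compounds shown do not separate the contribution of each group, and it remains open whether a lone methoxy or a lone methyl on the aryl ring would keep the low number. As far as these compounds go, it also remains open how the series would respond to an amine or a longer alkoxy chain in place of the methoxy group.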